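Bromo to iodo on the aromatic ring of compound 2

The source may hold more compounds than are shown below. What is called first, only, known or untested is meant among the compounds shown, and "the series" means these compounds.

Measured compounds in this series:
compound 1, `O=C(O)/C(S)=C/c1ccccc1Cl`: 11900 nM
compound 2, `O=C(O)/C(S)=C/c1cccc(Br)c1`: 4000 nM
compound 3, `O=C(O)/C(S)=C/c1c[nH]c2cc(Cl)ccc12`: 210 nM

All three numbers come from an assay on isolated protein for inhibition of Calpain-1 catalytic subunit (Sus scrofa), read by FRET; on this read-out lower numbers stand for stronger inhibition and higher numbers for weaker inhibition. Among them compound 2 holds the second highest number: compound 1 gives a higher number, and compound 3 gives a clearly lower one, both gaps being beyond the usual scatter. Compound 3 thus stands as the strongest of the three measured compounds, and compound 1 as the weakest; compound 2 sits between them, closer to compound 1 than to compound 3.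

The next compound, compound 4, `O=C(O)/C(S)=C/c1cccc(I)c1`, is not yet measured in this assay. It differs from compound 2 in a single place: iodo in place of bromo on an aromatic carbon

Going by the values given here, nothing among the measured compounds shows what a change of one halogen for another on this ring does; compound 1 and compound 2 differ in both the halogen and its place, and compound 3 carries a different core. The expectation is therefore cautious: the step from compound 2 to compound 4 is expected to be small, at most modestly toward a lower number, and quite possibly within the scatter, so that a 1.3-fold lower number from compound 2 to compound 4 (0.12 log units; within the scatter) is the estimated step. On that basis compound 4 is estimated at 3000 nM in this assay, with a range from 1200 nM to 8000 nM.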

Compound 4, half-maximal inhibitory concentration: 4300 nM
The estimate for compound 4 lay 1.4-fold (0.16 log units) below the measured number, within the range that was stated.
By their numbers in this assay, from the lowest: compound 3; then compounds 2 and 4 (each within the scatter of the next); then compound 1.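

In this assay, iodo in place of bromo on an aromatic carbon, meta to a group of 6 heavy atoms, gives a 1.1-fold higher number from compound 2 to compound 4 (0.03 log units; within the scatter), so this read-out does not separate the two halogens at this position. Going by these compounds alone, the pair is the only one so far that differs in one place, and it provides the series' sole direct reading of a halogen exchange on this ring, which the earlier compounds could not supply. No supporting measurement shown here accounts for this result.

Still open, as far as these compounds go, is whether this position tolerates groups other than bromo and iodo to the same degree, for example fluoro, an amine, a methoxy group or a carboxylic acid in the same place. Also open, from the compounds shown here alone, is whether the same exchange would read alike with the halogen elsewhere on the ring or on the core of compound 3 at 210 nM in this assay as the starting point.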